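Half-life of compound 4 in liver microsomes

The compounds below may be only part of what the source reports. "The series", "measured", "known", "first", "only" and "open" are said of these compounds alone.

Compound 1 `COc1ccc2[nH]c(C(=O)N3CC(=O)N(Cc4ccccc4)[C@@H](CN4CCCCC4)C3)cc2c1` gives 0.283 h
Compound 2 `O=C(c1cc2cc(C3CC3)ccc2[nH]1)N1CC(=O)N(Cc2ccccc2)[C@@H](CN2CCC(F)CC2)C1` gives 0.383 h
Compound 3 `COc1cccc(CN2C(=O)CN(C(=O)c3cc4cc(OC)ccc4[nH]3)C[C@@H]2c2ccccc2)c1` gives 0.118 h

These three values come from an ADME assay on microsomes from liver (Homo sapiens) for metabolic stability, with a stated time of 30 min, tested at 1 uM; a lower number here means that the compound disappears faster, a higher number that the compound lasts longer. Compound 1 stands within the scatter of compound 2, while compound 3 lies lower, beyond the scatter. Compound 4 `COc1ccc2[nH]c(C(=O)N3CC(=O)N(Cc4ccccc4)[C@@H](N4[C@H](C)CCC[C@@H]4C)C3)cc2c1` has not yet been measured. It carries 2,6-dimethylpiperidin-1-yl in place of (piperidin-1-yl)methyl on a saturated ring carbon. Among the compounds with values here, no two measured compounds differ in only one place, so the data offer no direct guide to this change. No step beyond the scatter is therefore expected, with only a slight lean towards a lower number. The estimated step is small (a 1.1-fold lower number from compound 1 to compound 4 (0.05 log units; within the scatter)). For compound 4 the expected half-life is 0.25 h, within an estimated range from 0.1 h to 0.55 h.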

Compound 4, half-life: 0.112 h
Compound 4: the middle estimate sits 2.2-fold (0.35 log units) above what was measured; the measured number falls inside the stated range.
By their numbers in this assay, from the lowest: compounds 4 and 3 (each within the scatter of the next); then compounds 1 and 2 (each within the scatter of the next).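

In this assay, this position now has its first readable step: 2,6-dimethylpiperidin-1-yl in place of (piperidin-1-yl)methyl on the saturated ring carbon gives a 2.5-fold lower number from compound 1 to compound 4 (0.40 log units; beyond the scatter). The half-life therefore responds to this change, even though the groups that leave and enter have the same hydrogen-bond donor and acceptor counts. Nothing measured here explains the step.

The change alters both the ring substitution and the attachment, so the two remain unseparated. As far as these compounds go, how a piperidin-1-yl set directly on that carbon, or a (morpholin-4-yl)methyl, would behave stays open.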